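The source may report more compounds than this note shows. Statements on the series, on what has been measured and on what is new or still open speak of the compounds shown alone.

Measured compounds in an assay on CHO cells for displacement of a labelled ligand from prostaglandin D2 receptor 2 (Homo sapiens), read by scintillation counting; a lower number here means a stronger inhibitor, a higher number a weaker inhibitor:
compound 1 `Cc1ccc(S(=O)(=O)N(C)CC(C)C)cc1C#Cc1cc(Cl)ccc1OCC(=O)O` — 4.2 nM
compound 2 `O=C(O)COc1cc(F)ccc1C#Cc1ccccc1Cl` — 4780 nM
compound 3 `CCCS(=O)(=O)c1ccc(C)c(C#Cc2cc(Cl)ccc2OC(C)C(=O)O)c1` — 1.2 nM

Compound 1 holds the second highest of the three numbers. Its nearest neighbour is compound 3, whose number is lower by a margin beyond the scatter; compound 2 lies far higher, the widest gap in the set. All three carry the shared core with an acid-bearing ether on one ring.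

Compound 4 `Cc1ccc(S(=O)(=O)N(C)C(C)C)cc1C#Cc1cc(Cl)ccc1OCC(=O)O` is not yet measured. The change from compound 1 reads: isopropyl in place of isobutyl on a sulfonamide nitrogen. Within the data shown here, no pair of measured compounds differs in this one place, so the step has no measured precedent here; compounds 2 and 3 vary at several places at once and do not isolate it.

The step of a 1.4-fold higher number from compound 1 to compound 4 (0.15 log units; within the scatter) is expected to be small, at most a slight move toward a higher number and most likely none beyond the scatter, since the acid, the alkyne and the sulfonyl group of compound 1 all remain. For compound 4 the estimate is 6 nM, with a range from 2.5 nM to 15 nM.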

Compound 4, inhibition constant: 3.8 nM
Estimate against measurement, compound 4: 1.6-fold (0.20 log units) above, within the range that was stated.
By their numbers in this assay, from the lowest: compound 3; then compounds 4 and 1 (each within the scatter of the next); then compound 2.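

Isopropyl in place of isobutyl on a sulfonamide nitrogen gives a 1.1-fold lower number from compound 1 to compound 4 (0.04 log units; within the scatter) in this assay and is the first step in the series that isolates a single place. With these two saturated chains on the sulfonamide nitrogen, compound 1 and compound 4 stand within the scatter of each other. This comparison covers only these two groups and does not extend to any other place on the shared core.

Open, as far as these compounds go, is whether a different group on this nitrogen, such as a cyclopropyl ring, a longer chain or a chain ending in an amine, would hold the same level in this assay or move it beyond the scatter. No measurement shown gives a reason for this flat step.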